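Chloro added to an inactive pyrimidinyl amide

A few compounds are considered here, and "the series" means these few. Any claim that something is new, unique, unknown or untested is made for them only; others in the source may bear on it.

Measured so far:
compound 1 `O=C(CN1CCN(c2ccc(Cl)cn2)CC1)Nc1cccnc1` — 23500 nM
compound 2 `O=C(CN1CCN(c2ccccn2)CC1)Nc1cncnc1` — "not active" (no number reported)

In an assay on cells for antagonist activity at D(4) dopamine receptor (Homo sapiens), read by luminescence and beta-arrestin recruitment, with a stated time of 90 min (on this read-out lower numbers stand for stronger inhibition and higher numbers for weaker inhibition), compound 1 gives 23500 nM, while compound 2 is reported only as "not active" (no number reported), with no single number to place it. Compound 3 `O=C(CN1CCN(c2ccc(Cl)cn2)CC1)Nc1cncnc1` differs from compound 2 by chloro in place of hydrogen on an aromatic carbon. Among the measured compounds shown here, no measured pair isolates this change, so its size in this assay cannot be read from the data; compound 3 is expected to remain weak, and a step beyond the scatter in either direction would not surprise. Compound 3 is estimated at 30000 nM, within 8000 nM to 100000 nM.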

Compound 3, half-maximal inhibitory concentration: > 100000 nM
Compound 3 gave a limit, no number; the forecaster's own chance of this, stated with the estimate: 60%; middle value at least 3.3-fold (0.52 log units) away from the limit.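

In this assay, the 5-chloropyridin-2-yl group does not give the pyrimidin-5-yl amide a measurable potency. Compound 3 carries only a limit, not a number: the limit of > 100000 nM in this assay, at which 1 of the 3 values shown sits. With chloro held in place, pyrimidin-5-yl in place of pyridin-3-yl on the amide-type nitrogen gives an at least 4.2-fold higher number from compound 1 to compound 3 (0.62 log units; beyond the scatter).

The step from compound 2 to compound 3 cannot be read, as neither compound has a number. From the compounds shown here alone, it remains open whether an amine or a methoxy group in place of chloro would bring the pyrimidin-5-yl amide into a readable range.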